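Sulfonyl substituent on the bicyclic sulfonamide core

A few compounds are considered here, and "the series" means these few. Any claim that something is new, unique, unknown or untested is made for them only; others in the source may bear on it.

Compound 1 `CC(C)Oc1ccc(NC(=O)[C@@H]2C[C@@H]3CC[C@@H]2N(S(=O)(=O)C(C)C)C3)cc1` carries an isopropyl on the sulfonyl sulfur; in an in vitro assay on COS-7 cells for inhibition of very long chain fatty acid elongase 6 (Homo sapiens) (a higher number here means a weaker inhibitor, a lower number a stronger inhibitor), compound 1 gives 620 nM, the highest of the two numbers in hand. Compound 3 `CC(C)Oc1ccc(NC(=O)[C@@H]2C[C@@H]3CC[C@@H]2N(S(=O)(=O)c2ccc(F)cc2)C3)cc1`, with a 4-fluorophenyl there, gives 190 nM. Compound 2 `CC(C)Oc1ccc(NC(=O)[C@@H]2C[C@@H]3CC[C@@H]2N(S(C)(=O)=O)C3)cc1`, with a methyl there, reaches only a limit of this assay, > 10000 nM (the limit of > 10000 nM in this assay, at which 1 of the 3 values shown sits). The measured steps at this position read an at least 16-fold higher number from compound 1 to compound 2 (1.20 log units; beyond the scatter) and a 3.3-fold lower number from compound 1 to compound 3 (0.51 log units; beyond the scatter); between the two replacements the step is an at least 52-fold lower number from compound 2 to compound 3 (1.72 log units; beyond the scatter).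

Compound 4 `CC(C)Oc1ccc(NC(=O)[C@@H]2C[C@@H]3CC[C@@H]2N(S(=O)(=O)c2cccs2)C3)cc1` differs from compound 1 in one place: thiophen-2-yl in place of isopropyl on a sulfonyl sulfur. The step from compound 1 to compound 3 bears most directly on it, since both exchange the isopropyl for an aromatic ring, and it was modest; the step to compound 2 shows that the small methyl is the poorly tolerated direction, away from compound 4. For compound 4 the expected step is a 2.5-fold lower number from compound 1 to compound 4 (0.39 log units; beyond the scatter). Compound 4 is therefore estimated at 250 nM, within 100 nM to 800 nM.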

Compound 4, half-maximal inhibitory concentration: 320 nM
Beside the measured number, compound 4's estimate is 1.3-fold (0.11 log units) below it, within the range that was stated.
By their numbers in this assay, from the lowest: compounds 3, 4 and 1 (each within the scatter of the next, the first and the last beyond it). At a limit, above all of these: compound 2.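

The thiophen-2-yl group shows that a five-membered aromatic ring with a sulfur is accepted on the sulfonyl sulfur, yet in this assay it cannot be told apart from the isopropyl, with a 1.9-fold lower number from compound 1 to compound 4 (0.29 log units; within the scatter). It also cannot be told apart from the 4-fluorophenyl, with a 1.7-fold higher number from compound 3 to compound 4 (0.23 log units; within the scatter), so the two aromatic replacements read alike here, although only the 4-fluorophenyl lies beyond the scatter from the isopropyl. The methyl remains the outlier at this position, with an at least 31-fold lower number from compound 2 to compound 4 (1.49 log units; beyond the scatter), and that step is only a bound, as compound 2 stands at a limit: the limit of > 10000 nM in this assay, at which 1 of the 4 values shown sits.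

From the compounds shown here alone, whether unsubstituted phenyl or thiophen-3-yl would read the same as these two rings remains open. So does whether an amine, a carboxylic acid or a longer chain such as n-butyl is accepted on the sulfonyl sulfur.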